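A few compounds are considered here, and "the series" means these few. Any claim that something is new, unique, unknown or untested is made for them only; others in the source may bear on it.

Of the compounds shown here, three have been measured in a functional assay on B16 cells (Mus musculus) for cytotoxicity, read by MTT assay, with a stated time of 48 h; on this read-out lower numbers stand for stronger inhibition and higher numbers for weaker inhibition. Compound 1 `CC1(C)CCCC2=CC=C(C=O)CC[C@]21C` gives 145000 nM, and compound 3 `C=C1CCC[C@]2(C)CCC(c3cn(CC(=O)Nc4ccc(C)cc4)nn3)=CC[C@@]12C` gives 210000 nM. Compound 2 `C=C1CCC[C@]2(C)CCC(c3cn(-c4cccc([N+](=O)[O-])c4)nn3)=CC[C@@]12C`, at 31700 nM, has the lowest of the three numbers, and its gaps to both others lie beyond the usual scatter.

Compound 4 `C=C1CCC[C@]2(C)CCC(c3cn(-c4cccc(OC)c4)nn3)=CC[C@@]12C` has not been measured yet. It keeps the core of compound 2 and changes one group: methoxy in place of nitro on an aromatic carbon. This is methoxy in place of nitro on an aromatic carbon, so 3-nitrophenyl becomes 3-methoxyphenyl. Among the compounds with values here, no measured pair isolates a single change, so the data give no direct guide to this swap. The only hint is the spread on the shared core, from compound 2 at 31700 nM to compound 3 at 210000 nM, with a different group attached. Starting from the lowest number, a modest move towards weaker inhibition seems more likely than a further drop. The expected change is a 1.9-fold higher number from compound 2 to compound 4 (0.28 log units; within the scatter) in this assay. For compound 4 the estimate is 60000 nM, with an expected range from 22000 nM to 160000 nM.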

Compound 4, half-maximal inhibitory concentration: 34700 nM
Compound 4: middle estimate off by 1.7-fold (0.24 log units), on the high side; the measured number falls inside the stated range.
By their numbers in this assay, from the lowest: compounds 2 and 4 (each within the scatter of the next); then compounds 1 and 3 (each within the scatter of the next).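

In this assay, within the data shown here, the step of a 1.1-fold higher number from compound 2 to compound 4 (0.04 log units; within the scatter) is the first comparison that isolates a single change, and it lies within the usual scatter. At this aromatic carbon, meta to a large group, 3-nitrophenyl and 3-methoxyphenyl therefore cannot be told apart on this read-out, even though the two groups share only an oxygen among their kinds of atom. The nitro group is thus not required for compound 2 to read as it does here, and nothing on hand explains why the two groups read alike.

The compounds shown leave open whether an amine, a carboxylic acid or a longer chain such as butoxy at this place would also read the same. They also leave open whether this swap would behave alike on another core or in another assay.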